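The compounds below may be only part of what the source reports. "The series", "measured", "known", "first", "only" and "open" are said of these compounds alone.

The measured compounds in an ADME assay on MT4 cells (Homo sapiens) for cytotoxicity, read by MTT assay; a lower number here means that less compound is tolerated, a higher number that more compound is tolerated:

compound 1 `S=C(Nc1ccccc1)OCCc1ccccn1` gives > 100000 nM, which is a limit of the assay rather than a number.
compound 2 `S=C(Nc1cccc(Cl)c1)OCCc1ccccn1` gives 47000 nM.
compound 3 `N#Cc1ccc(NC(=S)OCCc2ccccn2)cc1` gives 45000 nM.

Compound 1 thus stands at the edge of what this assay reports: its value is only a bound, the one described by the limit of > 100000 nM in this assay, at which 1 of the 3 values shown sits, so where it truly lies is not known as a number. Compound 4 `CC(=O)c1ccc(NC(=S)OCCc2ccccn2)cc1` differs from compound 1 by acetyl in place of hydrogen on an aromatic carbon. Two measured steps from compound 1 bear on this change, each putting a substituent onto the same ring of the shared core: an at least 2.1-fold lower number from compound 1 to compound 2 (0.32 log units; beyond the scatter) and an at least 2.2-fold lower number from compound 1 to compound 3 (0.34 log units; beyond the scatter). Both are stated as minimum sizes because they start from the bound the limit of > 100000 nM in this assay, at which 1 of the 3 values shown sits, rather than from a measured number. In both cases the substituent moved the value from a limit to a measured number, beyond the scatter. For compound 4 the acetyl group is expected to act in the same direction, with a step of about an at least 2.0-fold lower number from compound 1 to compound 4 (0.30 log units; that floor lies within the scatter). Compound 4 is therefore estimated to give 50000 nM in this assay , in a range from 20000 nM to 150000 nM.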

Compound 4, half-maximal cytotoxic concentration: >= 100000 nM
Compound 4 was reported as a limit; the forecaster's own chance of this, stated with the estimate: 25%; middle value at least 2.0-fold (0.30 log units) away from the limit.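

In this assay compound 4 gives >= 100000 nM, which is a limit of the assay and not a number. Putting acetyl in place of cyano at the same place on the ring, para to a large group, gives an at least 2.2-fold higher number from compound 3 to compound 4 (0.34 log units; beyond the scatter), so at this position the result depends on which group is present, not simply on whether the hydrogen has been replaced. Until now both substituted compounds, compound 2 and compound 3, had lower numbers than compound 1, and compound 4 goes against that pattern, although the step from compound 1 to compound 4 cannot be read, with a limit on each side.

On these data alone, it remains open where the true values of compound 1 and compound 4 lie, and so whether acetyl changes the tolerated concentration at all compared with hydrogen. As far as these compounds go, it is also open whether other groups at this place, such as an amine, a carboxylic acid or a longer chain, would give a result closer to that of compound 3 or that of compound 4.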